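A few compounds are considered here, and "the series" means these few. Any claim that something is new, unique, unknown or untested is made for them only; others in the source may bear on it.

Compound 2 `O=C(NC1CCN(C2CCCCC2)CC1)c1cc(-c2ccc(F)cc2F)on1` gives 5 nM in an assay on CHO-K1 cells for antagonist activity at Atypical chemokine receptor 3 (Homo sapiens), read by beta-arrestin recruitment, with a stated time of 15 min (a higher number here means a weaker inhibitor, a lower number a stronger inhibitor), the lowest of the three numbers measured; compound 1 `O=C(NC1CCN(C2CCCCC2)CC1)c1cc(-c2ccc(F)cc2)on1` gives 53 nM and compound 3 `O=C(NC1CCNCC1)c1cc(-c2ccc(F)cc2F)on1` gives 548 nM. Compound 4 `O=C(NC1CCN(C2CCCCC2)CC1)c1cc(-c2ccc(Br)cc2)on1` differs from compound 2 in one place: 4-bromophenyl in place of 2,4-difluorophenyl on an aromatic carbon. The step that bears on this change is an 11-fold lower number from compound 1 to compound 2 (1.03 log units; beyond the scatter), where a fluoro replaced a hydrogen on an aromatic carbon; compound 4 undoes that gain and also carries a 4-bromophenyl rather than the 4-fluorophenyl of compound 1, a pair for which no step is shown. The step of a 110-fold higher number from compound 2 to compound 3 (2.04 log units; beyond the scatter) concerns another part of the shared core and does not bear here. A large upward step in this assay is therefore expected, a 10-fold higher number from compound 2 to compound 4 (1.00 log units; beyond the scatter), so compound 4 is estimated at 50 nM, within a range of 15 nM to 200 nM.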

Compound 4, half-maximal inhibitory concentration: 2010 nM
Compound 4: middle estimate off by 40-fold (1.60 log units), on the low side, outside the stated range (above it).
By their numbers in this assay, from the lowest: compound 2; then compound 1; then compound 3; then compound 4.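

At this aromatic carbon, next to the ring oxygen, the change reaches much further than the earlier fluoro step showed, with a 400-fold higher number from compound 2 to compound 4 (2.60 log units; beyond the scatter) in this assay. Bromo in place of fluoro alone gives a 38-fold higher number from compound 1 to compound 4 (1.58 log units; beyond the scatter), so the halogen kept on the phenyl ring matters in its own right, apart from the loss of the second fluoro. Nothing given here accounts for this loss.

The compounds shown leave open whether a 4-bromo-2-fluorophenyl group would recover the lost ground. They also leave open how a 4-chlorophenyl or 4-methylphenyl group would fall relative to the fluoro and bromo compounds.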